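Thioether variation at the shared purine riboside core

The compounds below may be only part of what the source reports. "The series", "measured", "known", "first", "only" and "open" are said of these compounds alone.

Among the compounds with values here, compound 2 `Cc1cccc(CSc2nc(N)nc3c2ncn3[C@@H]2O[C@H](CO)[C@@H](O)[C@H]2O)n1` gives 11500000 nM in an assay on isolated protein for binding affinity to Equilibrative nucleoside transporter 1 (Homo sapiens) (a higher number here means a weaker inhibitor, a lower number a stronger inhibitor), the highest of the two numbers so far; compound 1 `CCCCSc1nc(N)nc2c1ncn2[C@@H]1O[C@H](CO)[C@@H](O)[C@H]1O` gives 12000 nM. Within the data shown here, the only step measured, a 960-fold higher number from compound 1 to compound 2 (2.98 log units; beyond the scatter), is large. Compound 3 `Nc1nc(SCCc2ccccc2)c2ncn([C@@H]3O[C@H](CO)[C@@H](O)[C@H]3O)c2n1` carries benzyl in place of 6-methylpyridin-2-yl on a saturated chain carbon bound to a sulfur. Among the measured compounds shown here, no step bears directly on this exchange, but the step from compound 1 to compound 2 shows that this position moves the number strongly, and benzyl returns toward a carbon-only group, so a large drop is expected, a 1200-fold lower number from compound 2 to compound 3 (3.06 log units; beyond the scatter). Compound 3 is estimated at 10000 nM, in the range 1000 nM to 100000 nM.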

Compound 3, half-maximal inhibitory concentration: 16200 nM
Compound 3: the middle estimate sits 1.6-fold (0.21 log units) below what was measured, within the range that was stated.
By their numbers in this assay, from the lowest: compounds 1 and 3 (each within the scatter of the next); then compound 2.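

In this assay, benzyl in place of 6-methylpyridin-2-yl gives a 710-fold lower number from compound 2 to compound 3 (2.85 log units; beyond the scatter), so the large penalty seen with compound 2 is not a general feature of an aromatic ring at this position. Phenyl in place of ethyl gives a 1.4-fold higher number from compound 1 to compound 3 (0.13 log units; within the scatter), leaving the phenethyl and butyl thioethers level. Nothing available explains either step.

Still open, on these data alone, is whether the pyridine nitrogen or the methyl group accounts for the value of compound 2. An unsubstituted pyridin-2-yl would separate the two, while a longer chain or a terminal amine would test the position further.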